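A few compounds are considered here, and "the series" means these few. Any claim that something is new, unique, unknown or untested is made for them only; others in the source may bear on it.

Going by the values given here, compound 2 `CCN1CCN(c2cc(C)c3cc(NC(=O)c4ccco4)ccc3n2)CC1` is one of two compounds measured so far in a functional assay on MCF7 cells (Homo sapiens) for antiproliferative activity, read by MTT assay, with a stated time of 72 h (a higher number here means a weaker inhibitor, a lower number a stronger inhibitor), where compound 2 gives 41200 nM. Compound 1 `CCN1CCN(c2cc(C)c3cc(NC(=O)c4ccccc4F)ccc3n2)CC1` gives 32600 nM in this assay. The two numbers lie within the scatter of each other: the step is a 1.3-fold higher number from compound 1 to compound 2 (0.10 log units; within the scatter). Compound 3 `CCN1CCN(c2cc(C)c3cc(NC(=O)c4ccc(F)cc4)ccc3n2)CC1` differs from compound 2 by 4-fluorophenyl in place of furan-2-yl on a carbonyl carbon. Among the compounds with values here, the only relevant step replaced 2-fluorophenyl with furan-2-yl on the carbonyl carbon and barely moved the number, so returning to a fluorophenyl group is expected to give a step of a 1.4-fold lower number from compound 2 to compound 3 (0.14 log units; within the scatter), again within the scatter. Compound 3 is therefore estimated at 30000 nM, between 12000 nM and 80000 nM.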

Compound 3, half-maximal inhibitory concentration: 4030 nM
Compound 3: the middle estimate sits 7.4-fold (0.87 log units) above what was measured; measured number below the stated range.
By their numbers in this assay, from the lowest: compound 3; then compounds 1 and 2 (each within the scatter of the next).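

The group on this carbonyl carbon is less interchangeable than the near-equal values of compound 1 and compound 2 suggested: in this assay, 4-fluorophenyl in place of furan-2-yl gives a 10-fold lower number from compound 2 to compound 3 (1.01 log units; beyond the scatter). The place of the fluorine on the phenyl ring also matters, since 4-fluorophenyl in place of 2-fluorophenyl gives an 8.1-fold lower number from compound 1 to compound 3 (0.91 log units; beyond the scatter), so a fluorophenyl group alone does not bring the gain. Nothing available explains these steps. On these data alone, whether plain phenyl, 4-chlorophenyl or 4-methoxyphenyl on the same carbonyl carbon would match compound 3 remains open.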